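The source may hold more compounds than are shown below. What is called first, only, known or untested is meant among the compounds shown, and "the series" means these compounds.

Measured so far:
Compound 1, `C[C@H](Nc1c(NCCCCCC(=O)NO)c(=O)c1=O)c1ccccc1`, gives < 5 uL/min in an ADME assay on cells (Hepatocyte, Homo sapiens) for pharmacokinetics, read by LC-MS, with a stated time of 90 min, tested at 1 uM; a lower number here means slower removal, a higher number faster removal of the compound; this is a limit of the assay.
Compound 2, `CC[C@H](Nc1c(NCCCCCC(=O)NO)c(=O)c1=O)c1ccccc1`, gives < 5 uL/min in this assay; this too is a limit of the assay.
Compound 3, `CCC(CCCCC(=O)NO)Nc1c(Nc2ccc(C(F)(F)F)cc2)c(=O)c1=O`, gives 25 uL/min in this assay.

Compound 1 and compound 2 share a core and differ only by methyl in place of hydrogen on a saturated chain carbon, two bonds along the chain from an aromatic carbon and a nitrogen on an aromatic ring. Both results sit at the limit of < 5 uL/min in this assay, at which 2 of the 3 values shown sit, so the step that the two limits leave unreadable from compound 1 to compound 2 cannot be read. Compound 3 has a different core, and the difference between the two cores is not broken down here; compound 3 is the only one of the three with a number rather than a limit.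

Compound 4, `CC(C)C(CCCCC(=O)NO)Nc1c(Nc2ccc(C(F)(F)F)cc2)c(=O)c1=O`, has not yet been measured. It differs from compound 3 by methyl in place of hydrogen on a saturated chain carbon bound to two saturated chain carbons. This is the same kind of change as that from compound 1 to compound 2, though the surroundings differ: in compound 2 the methyl enters two bonds along the chain from an aromatic carbon and a nitrogen on an aromatic ring, while in compound 4 it enters on a saturated chain carbon bound to two saturated chain carbons. Since the earlier step is unreadable, nothing measured sets the size of the coming one; the expected step of a 1.2-fold higher number from compound 3 to compound 4 (0.08 log units; within the scatter) is small, within the usual scatter. Compound 4 is thus estimated at 30 uL/min, from 12 uL/min to 70 uL/min.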

Compound 4, intrinsic clearance in a liver preparation (reported as CLH), per the amount of preparation that the assay uses: 27 uL/min
Compound 4: middle estimate off by 1.1-fold (0.05 log units), on the high side; measured number inside the range.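

In this assay, a methyl in place of a hydrogen on a saturated chain carbon bound to two saturated chain carbons gives a 1.1-fold higher number from compound 3 to compound 4 (0.03 log units; within the scatter), so on this core the change from ethyl to isopropyl makes no difference that stands out from the usual scatter. The same kind of change on the core of compound 1 cannot be read, because compound 1 and compound 2 are both limits of the assay and not numbers: the limit of < 5 uL/min in this assay, at which 2 of the 4 values shown sit. The result therefore holds for one core only and does not show that the change carries over from one core to the other, where the methyl also enters at a different place.

Still open, from the compounds shown here alone, is what a longer chain or a carboxylic acid in place of the isopropyl of compound 4 would do in this assay. Also open, going by these compounds, is what an amine in place of the trifluoromethyl of compound 4 would do there.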